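Swapping a Methyl-Branched Arm for a Brominated One

A few compounds are considered here, and "the series" means these few. Any claim that something is new, unique, unknown or untested is made for them only; others in the source may bear on it.

Of the compounds shown here, three built on a shared core have been tested in a functional assay on KYSE-450 cells (Homo sapiens) for inhibition, read by MTT assay, with a stated time of 48 h; a higher number here means a weaker inhibitor, a lower number a stronger inhibitor. Compound 2 `COc1ccc(CN(C(=O)C=C(C)C)c2cc(OC)c(OC)c(OC)c2)cc1O` gives 280 nM, the lowest of the three numbers. Compound 3 `C/C=C/C(=O)N(Cc1ccc(OC)c(Br)c1)c1cc(OC)c(OC)c(OC)c1` gives 10500 nM, and compound 1 `COc1ccc(CNc2cc(OC)c(OC)c(OC)c2)cc1Cl` gives 47800 nM; both lie beyond the usual scatter from compound 2, so compound 2 is the strongest inhibitor of the three. Compound 4 `COc1ccc(CN(C(=O)/C=C/CBr)c2cc(OC)c(OC)c(OC)c2)cc1O` has not yet been measured. It differs from compound 2 in one place: 3-bromoprop-1-en-1-yl in place of 2-methylprop-1-en-1-yl on a carbonyl carbon. Among the compounds with values here, no two measured compounds differ in a single place, so the measured data give no direct guide to this swap. The expected step is a 2.1-fold higher number from compound 2 to compound 4 (0.33 log units; beyond the scatter), a modest move toward a weaker inhibitor, close to the edge of the scatter. The expected value for compound 4 is 600 nM, between 120 nM and 3000 nM.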

Compound 4, half-maximal inhibitory concentration: 100 nM
For compound 4 the middle estimate is 6.0-fold (0.78 log units) above the measured one, and the stated range ends above it.
By their numbers in this assay, from the lowest: compound 4; then compound 2; then compound 3; then compound 1.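

Within the data shown here, the swap of 2-methylprop-1-en-1-yl for 3-bromoprop-1-en-1-yl on this carbonyl carbon gives a 2.8-fold lower number from compound 2 to compound 4 (0.45 log units; beyond the scatter), the first comparison here in which only one place changes. It shows that this arm is not fixed: replacing the branched end with a bromine-bearing one gives a stronger inhibitor, not a weaker one. Nothing measured here explains the step. Going by these compounds, whether bromine itself is needed remains open, since an arm ending in an amine, or a longer chain on the same carbonyl carbon, could move the number either way.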